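The compounds below may be only part of what the source reports. "The series", "measured", "known", "first", "only" and "open" are said of these compounds alone.

Compound 2 `O=S(=O)(/C=C/c1ccc(C(F)(F)F)cc1F)Cc1ccc(Nc2ncnc3ccccc23)cc1` gives 100000 nM in a functional assay on UACC-62 cells (Homo sapiens); on this read-out higher numbers stand for weaker inhibition of growth and lower numbers for stronger inhibition of growth. Compound 1 `O=S(=O)(/C=C/c1ccc(F)cc1F)Cc1ccc(Nc2ncnc3ccccc23)cc1` reaches only the limit of this assay, > 100000 nM. The step of a number no lower from compound 2 to compound 1 (the limit leaves the size open) thus carries the change (fluoro in place of trifluoromethyl on an aromatic carbon), its size left open by the limit (the limit of > 100000 nM in this assay, at which 1 of the 3 values shown sits). Compound 3 `O=S(=O)(/C=C/c1ccc(C(F)(F)F)cc1F)Cc1ccc(Nc2ncnc3ccc(Br)cc23)cc1` gives 22000 nM in this assay, a step of a 4.5-fold lower number from compound 2 to compound 3 (0.66 log units; beyond the scatter) on the change (bromo in place of hydrogen on an aromatic carbon), which is also how the core of compound 3 differs from the core of compound 2. Compound 4 `O=S(=O)(/C=C/c1ccc(F)cc1F)Cc1ccc(Nc2ncnc3ccc(Br)cc23)cc1` has not been measured in this assay; it differs from compound 3 by fluoro in place of trifluoromethyl on an aromatic carbon, the same change as from compound 2 to compound 1. Beside a number no lower from compound 2 to compound 1 (the limit leaves the size open), the step of a 2.7-fold higher number from compound 3 to compound 4 (0.44 log units; beyond the scatter) is expected, resting on compound 1 sitting at the limit (the limit of > 100000 nM in this assay, at which 1 of the 3 values shown sits). Compound 4 is estimated at 60000 nM, between 25000 nM and 150000 nM.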

Compound 4, concentration for 50% growth inhibition: 3000 nM
Beside the measured number, compound 4's estimate is 20-fold (1.30 log units) above it; the measured number lies below the stated range.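

The change from 2-fluoro-4-(trifluoromethyl)phenyl to 2,4-difluorophenyl does not carry over with one size between the two cores in this assay, where the bromo core shows a 7.3-fold lower number from compound 3 to compound 4 (0.87 log units; beyond the scatter): the same change on two cores in this assay, a number no lower (the limit leaves the size open) from compound 2 to compound 1 and a 7.3-fold lower number (0.87 log units; beyond the scatter) from compound 3 to compound 4, at least 7.3-fold (0.86 log units) apart, beyond the scatter of two such steps

Bromo in place of hydrogen likewise differs with the aromatic group, with an at least 33-fold lower number from compound 1 to compound 4 (1.52 log units; beyond the scatter) set against the smaller step on the other pair: the same change on two cores in this assay, a 4.5-fold lower number (0.66 log units; beyond the scatter) from compound 2 to compound 3 and an at least 33-fold lower number (1.52 log units; beyond the scatter) from compound 1 to compound 4, at least 7.3-fold (0.86 log units) apart, beyond the scatter of two such steps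

The value of compound 1, > 100000 nM, is a limit and not a number, so both gaps are lower bounds, and these four compounds give no rule for other cores: the limit of > 100000 nM in this assay, at which 1 of the 4 values shown sits.

Open, as far as these compounds go, is whether chloro or methoxy in place of bromo on the core of compound 4 gives the same pattern. Also open, from the compounds shown here alone, is how an amine or a carboxylic acid in place of the fluoro named in the change would read.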